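Swapping dimethylamino for ethoxy on the side chain

The source may report more compounds than this note shows. Statements on the series, on what has been measured and on what is new or still open speak of the compounds shown alone.

- compound 1 `C=CCCn1c(=O)c2[nH]cnc2n(CCC)c1=O`: 1.84 mg/kg
- compound 2 `CCCn1c(=O)n(CCN(C)C)c(=O)c2[nH]cnc21`: 5.65 mg/kg

Within the data shown here, in a functional assay on the whole organism for inhibition, with Cavia porcellus as the target (a lower number here means that less compound is needed, a higher number that more compound is needed for the effect), compound 2 gives 5.65 mg/kg, the higher of the two numbers so far, so more of it is needed for the effect. The next compound, compound 3 `CCCn1c(=O)n(CCOCC)c(=O)c2[nH]cnc21`, carries ethoxy in place of dimethylamino on a saturated chain carbon, two bonds along the chain from an aromatic nitrogen.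

Among the measured compounds shown here, only one measured step bears on this change: a 3.1-fold higher number from compound 1 to compound 2 (0.49 log units; beyond the scatter). There, dimethylamino replaced vinyl at the same place, and the number rose modestly. For the measured compounds named here, compound 3 loses dimethylamino again, but gains ethoxy rather than vinyl, and no measurement yet shows what ethoxy does here. A downward step of similar or smaller size therefore seems likely in this assay, though one step is thin evidence.

The expected change is a 1.9-fold lower number from compound 2 to compound 3 (0.27 log units; within the scatter). Compound 3 is estimated at 3 mg/kg, with an expected range of 1.2 mg/kg to 7.5 mg/kg.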

Compound 3, dose for half-maximal effect: 1.7 mg/kg
Compound 3: middle estimate off by 1.8-fold (0.25 log units), on the high side; low and high end bracket the measured number.
By their numbers in this assay, from the lowest: compounds 3 and 1 (each within the scatter of the next); then compound 2.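

In this assay the swap to ethoxy gives a 3.3-fold lower number from compound 2 to compound 3 (0.52 log units; beyond the scatter) and so cancels the rise that came with dimethylamino at this place on the chain. Ethoxy and vinyl can now be compared directly, and a 1.1-fold lower number from compound 1 to compound 3 (0.03 log units; within the scatter) means that the two groups cannot be told apart in this assay, while compound 2, with dimethylamino, stands apart from both compound 1 and compound 3. Nothing measured here explains this difference.

On these data alone, whether another amine, such as a piperidine or a primary amine, would behave like dimethylamino remains open. As far as these compounds go, it is also open whether a hydroxyl group or a longer chain ending in ethoxy would match ethoxy at this place.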